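Swapping the Furan Attachment Point on Compound 3

The compounds below may be only part of what the source reports. "The series", "measured", "known", "first", "only" and "open" are said of these compounds alone.

Of the compounds shown here, three sharing one core have been measured in an assay on membranes from HeLa cells for displacement of a labelled ligand from adenosine receptor A3 (Homo sapiens), read by scintillation counting, with a stated time of 180 min, tested at 1 uM; on this read-out higher numbers stand for more inhibition at the one concentration tested (going by the name of the read-out) and lower numbers for less inhibition. Compound 1 `CCCOC(=O)C1=C(C)NC(=O)NC1c1ccoc1` gives 11% in this assay. Compound 2 `CC1=C(C(=O)OCC(C)C)C(c2ccoc2)NC(=O)N1` differs from compound 1 by methyl in place of hydrogen on a saturated chain carbon bound to two saturated chain carbons; in this assay compound 2 gives 16%, and the step of a number 5 percentage points higher from compound 1 to compound 2 (within the scatter) lies within the scatter. Compound 3 `CCCC(=O)C1=C(C)NC(=O)NC1c1ccco1` gives 1% in this assay, the lowest of the three numbers: its gap to compound 1 is within the scatter, while its gap to compound 2 is beyond it.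

Compound 4 `CCCC(=O)C1=C(C)NC(=O)NC1c1ccoc1` has the same atoms as compound 3, joined differently: furan-3-yl in place of furan-2-yl on a saturated ring carbon. Going by the values given here, no measured pair differs in this one place alone, so no measured step bears on the change directly. Compounds 1 and 2 also carry furan-3-yl, but each differs from compound 3 in more than one place, so their values cannot be read as the effect of the furan alone. Among the compounds with values here, with no step to lean on, the step is expected to be small, a number 7 percentage points higher from compound 3 to compound 4 (within the scatter), not beyond the scatter. Compound 4 is therefore estimated at 8%, between 0% and 22%.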

Compound 4, a percentage reported as inhibition, at one concentration (the size of the read-out at that concentration, not a potency): 2%
For compound 4 the middle estimate is 6 percentage points above the measured one; low and high end bracket the measured number.
By their numbers in this assay, from the lowest: compounds 3, 4, 1 and 2 (each within the scatter of the next, the first and the last beyond it).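

In this assay, changing the furan attachment point gives a number 1 percentage points higher from compound 3 to compound 4 (within the scatter), so on this saturated ring carbon, with a propylcarbonyl group on the ring atom next to it, furan-2-yl and furan-3-yl cannot be told apart by this read-out. Going by these compounds alone, compound 4 also makes it possible, for the first time, to read the group on the carbonyl carbon alone while furan-3-yl stays in place: propyl in place of propoxy gives a number 9 percentage points lower from compound 1 to compound 4 (within the scatter), whereas propyl in place of isobutoxy gives a number 14 percentage points lower from compound 2 to compound 4 (beyond the scatter), and only this second step is large enough to count as a real difference. There is no independent measurement here that could explain either the flat furan swap or the step on the carbonyl carbon.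

From the compounds shown here alone, whether furan-2-yl and furan-3-yl would also match with propoxy or isobutoxy on the carbonyl carbon remains open, since the furan change can be read only with propyl there. Also open, going by these compounds, is how an amine or a longer chain on the carbonyl carbon would compare with these groups, and whether either could raise the inhibition seen at this single concentration.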